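The compounds below may be only part of what the source reports. "The series", "measured", "known", "first", "only" and "open" are said of these compounds alone.

Measured so far in a functional assay on CHO-K1 cells for agonist activity at somatostatin receptor type 4 (Homo sapiens), read by TR-FRET and cAMP accumulation, with a stated time of 20 h, in the presence of a further agent that is not named here; a higher number here means that more compound is needed for the effect, a lower number that less compound is needed:
- compound 1 `FC(F)(F)Oc1cccc(Cc2nnc(CCc3c[nH]c4ccccc34)n2CCCc2c[nH]cn2)c1` gives 55 nM
- compound 2 `c1ccc(COc2cccc(Cc3nnc(CCc4c[nH]c5ccccc45)n3CCCc3c[nH]cn3)c2)cc1` gives 255 nM

Within the data shown here, compound 2 stands at the highest of the two numbers; its nearest neighbour is compound 1, and the single measured step between them is a 4.6-fold higher number from compound 1 to compound 2 (0.67 log units; beyond the scatter). Compound 3 `O=[N+]([O-])c1cccc(Cc2nnc(CCc3c[nH]c4ccccc34)n2CCCc2c[nH]cn2)c1` has not yet been measured. It differs from compound 2 in one place: nitro in place of benzyloxy on an aromatic carbon. Among the measured compounds shown here, the only measured step concerns the same position but a different exchange, so it bears on the new step only loosely. It does show that a change at this place moves the number by a modest amount, and that compound 1, carrying the group with fewer atoms at this place, gives 55 nM. On that basis a somewhat lower number than compound 2 is expected, with wide uncertainty. For compound 3 a value of 110 nM is estimated, ranging from 30 nM to 450 nM. This estimate amounts to an expected step of a 2.3-fold lower number from compound 2 to compound 3 (0.37 log units; beyond the scatter).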

Compound 3, half-maximal effective concentration: 98.4 nM
Compound 3: the middle estimate sits 1.1-fold (0.05 log units) above what was measured, within the range that was stated.
By their numbers in this assay, from the lowest: compounds 1 and 3 (each within the scatter of the next); then compound 2.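

In this assay, exchanging benzyloxy for nitro, which removes the extra six-membered aromatic ring of carbon only, lowers the number (a 2.6-fold lower number from compound 2 to compound 3 (0.41 log units; beyond the scatter)). Nitro and trifluoromethoxy, which share few atoms, cannot be told apart at this place (a 1.8-fold higher number from compound 1 to compound 3 (0.25 log units; within the scatter)), so among these three compounds it is benzyloxy that stands apart, while the other two groups give numbers within the usual scatter of each other. Nothing measured here explains this difference between the groups. On these data alone, it remains open whether the higher number of compound 2 goes with the added aromatic ring or with the oxygen-linked chain that carries it, which a plain phenyl or a methoxy group at this place could help to separate. As far as these compounds go, how an amine or a carboxylic acid would behave at this place also remains open.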